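The source may report more compounds than this note shows. Statements on the series, on what has been measured and on what is new or still open speak of the compounds shown alone.

Compound 1 `CC1=C(/C=C/C(=O)/C=C/c2ccccc2C(F)(F)F)C(C)(C)CCC1O` gives 2900 nM
Compound 2 `CC1=C(/C=C/C(=O)/C=C/c2cccc(C(F)(F)F)c2)C(C)(C)CCC1O` gives 740 nM

In a functional assay on LNCaP cells (Homo sapiens) for cytotoxicity, read by MTT assay, with a stated time of 72 h (on this read-out higher numbers stand for weaker inhibition and lower numbers for stronger inhibition), compound 2 holds the lower of the two numbers, beyond the scatter from compound 1. Compound 3 `CC1=C(/C=C/C(=O)/C=C/c2cc(C(F)(F)F)ccc2C(F)(F)F)C(C)(C)CCC1O` follows from compound 2 by the change trifluoromethyl in place of hydrogen on an aromatic carbon in which trifluoromethyl takes the place of hydrogen on an aromatic carbon, ortho to a large group and para to a trifluoromethyl group. Compound 1 also has a trifluoromethyl group ortho to a large group and gives 2900 nM as its number, so a moderate rise toward weaker inhibition is expected in this assay for this change. The estimated step is a 2.2-fold higher number from compound 2 to compound 3 (0.33 log units; beyond the scatter) in size, slightly beyond the scatter. Compound 3 is expected at 1600 nM within an estimated range from 500 nM to 4500 nM in this measurement.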

Compound 3, half-maximal inhibitory concentration: 3200 nM
Compound 3: the middle estimate sits 2.0-fold (0.30 log units) below what was measured; low and high end bracket the measured number.
By their numbers in this assay, from the lowest: compound 2; then compounds 1 and 3 (each within the scatter of the next).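

In this assay, trifluoromethyl on the aromatic carbon ortho to a large group and para to a trifluoromethyl group weakens inhibition, with a 4.3-fold higher number from compound 2 to compound 3 (0.64 log units; beyond the scatter) as the step. The other single change leading to compound 3, again trifluoromethyl in place of hydrogen on an aromatic carbon, gives a 1.1-fold higher number from compound 1 to compound 3 (0.04 log units; within the scatter) and so adds nothing that can be told from the scatter. No measurement here explains either step. The compounds shown leave open whether the loss is specific to trifluoromethyl or would also follow a methoxy group or an amine on that carbon.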